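This account rests on a few compounds, and the source may have more. Where it says the series, first, only, none or still open, it means among the compounds named here.

For the measured compounds named here, in a functional assay on DU-145 cells (Homo sapiens) for antiproliferative activity, read by MTT assay, with a stated time of 24 h (on this read-out lower numbers stand for stronger inhibition and higher numbers for weaker inhibition), compound 3 `COc1cc(-c2cc(/C=C/C(=O)c3ccc(C)cc3)nc3cc(-c4ccccc4)nn23)cc(OC)c1OC` gives 27100 nM, the second highest of the three numbers measured so far. Compound 1 `COc1cc(C(=O)/C=C/c2cc(-c3cc(OC)c(OC)c(OC)c3)n3nc(-c4ccccc4)cc3n2)cc(OC)c1OC` gives 34900 nM and compound 2 `COc1cc(-c2cc(C(=O)/C=C/c3ccccc3)nc3cc(-c4ccccc4)nn23)cc(OC)c1OC` gives 16300 nM; the steps of a 1.3-fold lower number from compound 1 to compound 3 (0.11 log units; within the scatter) and a 1.7-fold higher number from compound 2 to compound 3 (0.22 log units; within the scatter) both stay within the scatter, so the three compounds sit close together on this read-out. Compound 4 `COc1cc(-c2cc(/C=C/C(=O)c3ccccc3)nc3cc(-c4ccccc4)nn23)cc(OC)c1OC` differs from compound 3 by hydrogen in place of methyl on an aromatic carbon. Going by the values given here, no measured pair isolates exactly this change; the steps that touch the same part of the molecule were small, and a change of a single carbon at this position is expected to move the number by no more than the scatter in either direction. The step of a 1.1-fold lower number from compound 3 to compound 4 (0.04 log units; within the scatter) is therefore expected to be negligible. Compound 4 is estimated at 25000 nM, with a range from 10000 nM to 60000 nM.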

Compound 4, half-maximal inhibitory concentration: 34300 nM
Estimate against measurement, compound 4: 1.4-fold (0.14 log units) below, and the stated range covers the measured number.
By their numbers in this assay, from the lowest: compounds 2, 3, 4 and 1 (each within the scatter of the next, the first and the last beyond it).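

In this assay, the step of a 1.3-fold higher number from compound 3 to compound 4 (0.10 log units; within the scatter) and the step of a 1.0-fold lower number from compound 1 to compound 4 (0.01 log units; within the scatter) both stay within the scatter, so neither the methyl nor the three methoxy groups on this ring make a readable difference. For the compounds shown here, the step of a 2.1-fold higher number from compound 2 to compound 4 (0.32 log units; beyond the scatter) is the first one beyond the scatter, though only modestly, and it comes with the swap from (2-phenylethenyl)carbonyl to 2-benzoylethenyl; compound 3, which carries the same linker as compound 4, goes against it, as its step from compound 2 stays within the scatter. No available evidence explains these numbers. The compounds shown carry only hydrogen, methyl or methoxy on this ring, so what an amine or a carboxylic acid would do here stays open.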